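The source may report more compounds than this note shows. Statements on the series, on what has been measured and on what is new or still open speak of the compounds shown alone.

Measured in a functional assay on MGC-803 cells (Homo sapiens) for inhibition, read by sulforhodamine B assay; on this read-out lower numbers stand for stronger inhibition and higher numbers for weaker inhibition:
compound 1 `CCc1ccc(NC2=CC(=O)c3c(nc4n3[C@H]3OC[C@@H](O)[C@H]3OC4)C2=O)cc1`: 1110 nM
compound 2 `Cc1ccc(NC2=CC(=O)c3c(nc4n3[C@H]3OC[C@@H](O)[C@H]3OC4)C2=O)cc1C`: 1050 nM
compound 3 `COc1ccc(NC2=CC(=O)c3c(nc4n3[C@H]3OC[C@@H](O)[C@H]3OC4)C2=O)cc1`: 2150 nM

The highest number of the three belongs to compound 3 at 2150 nM, with a 2.0-fold higher number from compound 2 to compound 3 (0.31 log units; beyond the scatter) and a 1.9-fold higher number from compound 1 to compound 3 (0.29 log units; within the scatter).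

Compound 4 `COc1cccc(NC2=CC(=O)c3c(nc4n3[C@H]3OC[C@@H](O)[C@H]3OC4)C2=O)c1` has 3-methoxyphenyl in place of 4-methoxyphenyl on an amine nitrogen. Among the compounds with values here, no measured step moves a group in this way, so only the general size of steps bears on it. Those steps remain small, as a 1.1-fold lower number from compound 1 to compound 2 (0.02 log units; within the scatter) and the two above show. No step beyond the scatter is therefore expected in this assay. The expected change is a 1.2-fold lower number from compound 3 to compound 4 (0.08 log units; within the scatter). For compound 4 the estimate is 1800 nM, with an expected range of 900 nM to 3800 nM.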

Compound 4, half-maximal inhibitory concentration: 1790 nM
For compound 4 the middle estimate is 1.0-fold (0.00 log units) above the measured one, within the range that was stated.
By their numbers in this assay, from the lowest: compounds 2, 1, 4 and 3 (each within the scatter of the next, the first and the last beyond it).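

Swapping 4-methoxyphenyl for 3-methoxyphenyl on the amine nitrogen is the first change of substituent position in the series, and in this assay it stays within the scatter (a 1.2-fold lower number from compound 3 to compound 4 (0.08 log units; within the scatter)). Compound 4 also stays within the scatter of both alkyl-substituted analogues (a 1.7-fold higher number from compound 2 to compound 4 (0.23 log units; within the scatter); a 1.6-fold higher number from compound 1 to compound 4 (0.21 log units; within the scatter)). No supporting evidence bears on this result.

From the compounds shown here alone, whether an amine or a carboxylic acid on the phenyl ring would produce a step beyond the scatter remains open. The same question holds for a longer alkoxy chain in place of methoxy.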